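A few compounds are considered here, and "the series" means these few. Any claim that something is new, unique, unknown or untested is made for them only; others in the source may bear on it.

Measured so far:
- compound 1 `O=C(C1CC12CCC2)N1CCc2nc(C#Cc3ccccc3)sc2C1`: 3.9 nM
- compound 2 `O=C(C1CC(F)C1)N1CCc2nc(C#Cc3ccccc3)sc2C1`: 85 nM

In an assay on HEK293 cells for positive allosteric modulation of metabotropic glutamate receptor 5 (Homo sapiens), read by FLIPR, with a stated time of 1 h (on this read-out higher numbers stand for an effect only at larger amounts of compound and lower numbers for an effect already at smaller amounts), compound 2 holds the highest of the two numbers, set apart from compound 1 by a 22-fold higher number from compound 1 to compound 2 (1.34 log units; beyond the scatter). Compound 3 `O=C(C1CCCO1)N1CCc2nc(C#Cc3ccccc3)sc2C1` carries oxolan-2-yl in place of 3-fluorocyclobutyl on a carbonyl carbon. Among the compounds with values here, the only step measured so far, a 22-fold higher number from compound 1 to compound 2 (1.34 log units; beyond the scatter), shows that exchanges on this carbonyl carbon move the number by a large amount; no measured step contains the oxolan-2-yl group itself, so its direction cannot be drawn from the data. For compound 3 a number near compound 2 is expected, with the uncertainty of an untested group: the expected step is a 1.8-fold higher number from compound 2 to compound 3 (0.25 log units; within the scatter). Compound 3 is estimated at 150 nM, range 30 nM to 800 nM.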

Compound 3, half-maximal effective concentration: 790 nM
Beside the measured number, compound 3's estimate is 5.3-fold (0.72 log units) below it; measured number inside the range.
By their numbers in this assay, from the lowest: compound 1; then compound 2; then compound 3.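

With the count of 5 heavy atoms unchanged, oxolan-2-yl in place of 3-fluorocyclobutyl on the carbonyl carbon still gives a 9.3-fold higher number from compound 2 to compound 3 (0.97 log units; beyond the scatter) in this assay, so this count alone does not set the number at this position. The series now spans a 200-fold higher number from compound 1 to compound 3 (2.31 log units; beyond the scatter) through exchanges at this one place. Nothing here gives a reason for the shift.

The step changes ring size and ring atoms together, leaving their separate contributions open. Cyclopentyl and oxolan-3-yl groups on the same carbonyl carbon would help separate them.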